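A few compounds are considered here, and "the series" means these few. Any claim that something is new, unique, unknown or untested is made for them only; others in the source may bear on it.

Compound 1 `COc1ccc(-c2c(C#N)c(N)nc(SCc3csc(-c4ccc(Cl)c(Cl)c4)n3)c2C#N)cc1` holds the lower of the two numbers recorded in an assay on CHO cells for displacement of a labelled ligand from adenosine receptor A1 (Homo sapiens); on this read-out lower numbers stand for stronger inhibition and higher numbers for weaker inhibition: compound 1 gives 11 nM, while compound 2 `COc1ccc(-c2c(C#N)c(N)nc(SCc3nc(-c4ccc(Cl)cc4)sc3Cl)c2C#N)cc1` gives 88 nM in this assay, a gap that lies beyond the scatter of the measurement. Compound 3 `COc1ccc(-c2c(C#N)c(N)nc(SCc3csc(-c4ccc(Br)cc4)n3)c2C#N)cc1` differs from compound 1 in one place: 4-bromophenyl in place of 3,4-dichlorophenyl on an aromatic carbon. For the measured compounds named here, with no measured pair of this kind to lean on, a modest weakening is expected for compound 3, a step of a 2.3-fold higher number from compound 1 to compound 3 (0.36 log units; beyond the scatter) in this assay, still well inside the span the two measured compounds mark out. Compound 3 is therefore estimated at 25 nM, within a range of 8 nM to 80 nM.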

Compound 3, inhibition constant: 3.8 nM
Compound 3: middle estimate off by 6.6-fold (0.82 log units), on the high side, and the stated range ends above it.
By their numbers in this assay, from the lowest: compound 3; then compound 1; then compound 2.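

At this aromatic carbon of the five-membered ring, 4-bromophenyl in place of 3,4-dichlorophenyl gives a 2.9-fold lower number from compound 1 to compound 3 (0.46 log units; beyond the scatter) in this assay, so the position does not need the 3,4-dichlorophenyl group for a low number. The swap changes both the halogen and the number of halogens at once, and this single step cannot separate the two. Nothing at hand explains the step.

Going by these compounds, it remains open how a plain phenyl or a 4-methoxyphenyl group would read at this carbon, and whether a halogen on the phenyl ring is needed at all.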